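This account rests on a few compounds, and the source may have more. Where it says the series, first, only, none or still open, it means among the compounds named here.

In a functional assay on K562 cells (Homo sapiens) for antiproliferative activity, read by CellTiter-Glo, with a stated time of 72 h (a higher number here means that more compound is needed for the effect, a lower number that less compound is needed), compound 1 `CCCCCNc1ncnc2c1ncn2[C@@H]1O[C@H](COS(N)(=O)=O)[C@@H](O)[C@H]1O`, which carries a pentyl group, gives 181 nM. Compound 2 `CC(C)(C)CC(C)(C)Nc1ncnc2c1ncn2[C@@H]1O[C@H](COS(N)(=O)=O)[C@@H](O)[C@H]1O` gives > 1000 nM, which is a limit of the assay and not a number. Compound 3 `COCCNc1ncnc2c1ncn2[C@@H]1O[C@H](COS(N)(=O)=O)[C@@H](O)[C@H]1O` gives > 1000 nM, which is also a limit. Compound 2 therefore stands at the limit of > 1000 nM in this assay, at which 2 of the 3 values shown sit.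

Compound 4 `NS(=O)(=O)OC[C@H]1O[C@@H](n2cnc3c(N4CCC5CCCCC5C4)ncnc32)[C@H](O)[C@@H]1O` keeps the shared core but exchanges the (1,1,3,3-tetramethylbutyl)amino group of compound 2 on an aromatic carbon: a group of 10 heavy atoms (9 carbon, 1 nitrogen; one six-membered non-aromatic ring of carbon only, one six-membered non-aromatic ring with 1 hetero atom) in place of a group of 9 heavy atoms (8 carbon, 1 nitrogen; no ring), on an aromatic carbon. Among the compounds with values here, no measured step makes this exact change. The nearest evidence is an at least 5.5-fold higher number from compound 1 to compound 2 (0.74 log units; beyond the scatter), together with an at least 5.5-fold higher number from compound 1 to compound 3 (0.74 log units; beyond the scatter). Both steps move away from the pentyl group, and both end at the limit. Among these three compounds, only compound 1 gives a number, so no step towards a lower number is expected in this assay. Compound 4 will probably remain weak, perhaps again reported only as a limit.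

The expected change is a step that the limit leaves unreadable from compound 2 to compound 4. Compound 4 is estimated at 2000 nM, with an expected range from 400 nM to 10000 nM.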

Compound 4, half-maximal effective concentration: > 1000 nM
Compound 4: no number, only a limit; the forecaster's own chance of this, stated with the estimate: 70%; the middle value does not contradict the limit.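

In this assay compound 4 gives > 1000 nM, which is a limit and not a number, so a group with two non-aromatic rings and no hydrogen-bond donor on this aromatic carbon also gives no number. Putting this two-ring group in place of the pentylamino group gives an at least 5.5-fold higher number from compound 1 to compound 4 (0.74 log units; beyond the scatter). The steps that join this result to the other two limits cannot be read, and the pentyl compound remains the only one of the four with a number: the limit of > 1000 nM in this assay, at which 3 of the 4 values shown sit.

The compounds shown do not place compound 2, compound 3 and compound 4 in any order among themselves. They also leave open whether a butyl or hexyl chain, or a benzyl group, on the nitrogen would give a number in this assay.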